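A few compounds are considered here, and "the series" means these few. Any claim that something is new, unique, unknown or untested is made for them only; others in the source may bear on it.

Compound 1 `O=c1cc(-c2ccccc2)oc2ccc(OCCCCCCN3CCC(O)CC3)cc12` shows the higher of the two numbers in an assay on isolated protein (Cavia porcellus) with Sigma non-opioid intracellular receptor 1 (Homo sapiens) as the target, read by radioligand binding (a lower number here means a stronger inhibitor, a higher number a weaker inhibitor), where compound 1 gives 121 nM; compound 2 `CCOC(=O)C1CCN(CCCCCCOc2ccc3oc(-c4ccccc4)cc(=O)c3c2)CC1` gives 102 nM in this assay, and the step of a 1.2-fold lower number from compound 1 to compound 2 (0.07 log units; within the scatter) is within the scatter. Compound 3 `O=c1cc(-c2cccnc2)oc2ccc(OCCCCCCN3CCC(O)CC3)cc12` differs from compound 1 by pyridin-3-yl in place of phenyl on an aromatic carbon. Within the data shown here, no measured step touches that aromatic ring, so the only known step, a 1.2-fold lower number from compound 1 to compound 2 (0.07 log units; within the scatter), offers no direct guide; a small change in this assay, if any, is expected. Compound 3 is therefore estimated at 200 nM, within 70 nM to 600 nM. The expected step of a 1.7-fold higher number from compound 1 to compound 3 (0.22 log units; within the scatter) is judged near the edge of scatter.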

Compound 3, half-maximal inhibitory concentration: 210 nM
Compound 3: the middle estimate sits 1.1-fold (0.02 log units) below what was measured; the range from low to high includes it.
By their numbers in this assay, from the lowest: compounds 2, 1 and 3 (each within the scatter of the next, the first and the last beyond it).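

Among these compounds, this is the first measured step at this aromatic carbon next to the ring oxygen. In this assay, pyridin-3-yl in place of phenyl gives a 1.7-fold higher number from compound 1 to compound 3 (0.24 log units; within the scatter), so a ring nitrogen can enter here without moving the reading beyond the scatter. Nothing available explains this reading.

Still open, as far as these compounds go, is whether pyridin-4-yl, pyridin-2-yl or a methoxyphenyl group at this carbon would move the number beyond the scatter. From the compounds shown here alone, it is also open how pyridin-3-yl would behave alongside the ethoxycarbonyl group of compound 2.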